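Removing the methylene bridge to the triazole

A few compounds are considered here, and "the series" means these few. Any claim that something is new, unique, unknown or untested is made for them only; others in the source may bear on it.

Compound 2 `OC[C@H](NC1CCN(CCCc2c[nH]c3ccc(Cn4cncn4)cc23)CC1)c1ccccc1` stands at the high end of the three numbers in an assay on CHO cells for displacement of a labelled ligand from 5-hydroxytryptamine receptor 1D (Homo sapiens) (on this read-out higher numbers stand for weaker inhibition and lower numbers for stronger inhibition), giving 23 nM, whereas compound 1 `OC[C@H](NC1CCN(CCCc2c[nH]c3ccc(-n4ccnc4)cc23)CC1)c1ccccc1` gives 0.7 nM and compound 3 `COC[C@H](NC1CCN(CCCc2c[nH]c3ccc(Cn4cncn4)cc23)CC1)c1ccc(F)cc1` gives 5 nM. The gaps are the steps of a 33-fold higher number from compound 1 to compound 2 (1.52 log units; beyond the scatter) and a 4.6-fold lower number from compound 2 to compound 3 (0.66 log units; beyond the scatter). Compound 4 `OC[C@H](NC1CCN(CCCc2c[nH]c3ccc(-n4cncn4)cc23)CC1)c1ccccc1` carries 1H-1,2,4-triazol-1-yl in place of (1H-1,2,4-triazol-1-yl)methyl on an aromatic carbon. Within the data shown here, only the step from compound 1 to compound 2 bears on this change; it was large, but it exchanged the ring as well as the linker, so only part of it can be read across. A lower number is expected for compound 4, with an estimated step of a 9.2-fold lower number from compound 2 to compound 4 (0.96 log units; beyond the scatter). Compound 4 is therefore estimated at 2.5 nM, within a range of 0.6 nM to 10 nM.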

Compound 4, half-maximal inhibitory concentration: 4.1 nM
Estimate against measurement, compound 4: 1.6-fold (0.21 log units) below, within the range that was stated.
By their numbers in this assay, from the lowest: compound 1; then compounds 4 and 3 (each within the scatter of the next); then compound 2.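

With the ring held as 1H-1,2,4-triazol-1-yl, removing the methylene alone gives a 5.6-fold lower number from compound 2 to compound 4 (0.75 log units; beyond the scatter) in this assay, so the linker counts on its own. With the direct attachment held, exchanging 1H-imidazol-1-yl for 1H-1,2,4-triazol-1-yl gives a 5.9-fold higher number from compound 1 to compound 4 (0.77 log units; beyond the scatter), so the ring counts too, and the large step between compound 1 and compound 2 now divides into two parts, each beyond the scatter. Nothing available explains either step. The compounds shown leave open whether the direct attachment combines with the 1-(4-fluorophenyl)-2-methoxyethyl group of compound 3. From the compounds shown here alone, how a tetrazole on this aromatic carbon, or a longer chain carrying the triazole, would read in this assay also remains open.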